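Swapping the Amide Substituent on a Shared Core

This account rests on a few compounds, and the source may have more. Where it says the series, first, only, none or still open, it means among the compounds named here.

Measured compounds:
compound 1, `Cc1c(Oc2cnc(C(=O)NCCO)cn2)ccc2c1B(O)OC2`: 13100 nM
compound 2, `CCC[C@H](CO)NC(=O)c1cnc(Oc2ccc3c(c2C)B(O)OC3)cn1`: 10800 nM

In an ADME assay on the whole organism (plasma, strain CD1) for pharmacokinetics, with Mus musculus as the target, read by LC-MS, at a dose of 5 mg/kg by the oral route (a higher number here means more compound in the circulation at the dose given, a lower number less compound in the circulation), compound 1 gives 13100 nM and compound 2 gives 10800 nM. Compound 2 holds the lowest of the two numbers, and its nearest neighbour is compound 1; the step between them, a 1.2-fold lower number from compound 1 to compound 2 (0.08 log units; within the scatter), lies within the scatter, so the two numbers cannot be ordered.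

Compound 3, `Cc1c(Oc2cnc(C(=O)N3CC(C)(O)C3)cn2)ccc2c1B(O)OC2`, is not yet measured in this assay. Its change from compound 2 is 3-hydroxy-3-methylazetidin-1-yl in place of (1-(hydroxymethyl)butyl)amino on a carbonyl carbon. Going by the values given here, only one measured step exists, a 1.2-fold lower number from compound 1 to compound 2 (0.08 log units; within the scatter), and it also alters the group on the carbonyl carbon while leaving the amide hydrogen in place; it stayed within the scatter. Among the compounds with values here, no measured step replaces the amide hydrogen or brings in a four-membered ring on the nitrogen, so nothing bears directly on the ring itself. On this thin evidence the expected step is a 1.0-fold higher number from compound 2 to compound 3 (0.01 log units; within the scatter), none beyond the scatter. Compound 3 is therefore estimated at 11000 nM, with a range from 4000 nM to 30000 nM.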

Compound 3, maximal plasma concentration: 11000 nM
The estimate for compound 3 equals the measured number at the digits printed; measured number inside the range.
By their numbers in this assay, from the lowest: compounds 2, 3 and 1 (each within the scatter of the next).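

Going by these compounds alone, the 3-hydroxy-3-methylazetidin-1-yl group is the first group on this carbonyl carbon to lack the amide hydrogen and the first to bring in a ring, and in this assay neither difference moves the number outside the scatter. Its replacement of (1-(hydroxymethyl)butyl)amino gives a 1.0-fold higher number from compound 2 to compound 3 (0.01 log units; within the scatter), and its replacement of (2-hydroxyethyl)amino gives a 1.2-fold lower number from compound 1 to compound 3 (0.08 log units; within the scatter), so the three compounds cannot be ordered and the open-chain groups and the four-membered ring stand level at this position. No measurement shown here accounts for the numbers staying together.

All three groups on the carbonyl carbon carry a hydroxy group, so the compounds leave open whether a plain azetidin-1-yl ring or a simple methylamino group, without that hydroxy group, would stay within the scatter as well. They also leave open whether a larger ring such as piperidine or morpholine, or a chain ending in a carboxylic acid or an amine, would shift the maximal plasma concentration at this position.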